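Linker change at the carbonyl of compound 3

The source may hold more compounds than are shown below. What is called first, only, known or untested is meant among the compounds shown, and "the series" means these compounds.

Measured compounds and their numbers in an assay on mitochondria (strain BALB/c) for inhibition of glycerol-3-phosphate acyltransferase 1, mitochondrial (Mus musculus), read by scintillation counting, with a stated time of 10 min; on this read-out lower numbers stand for stronger inhibition and higher numbers for weaker inhibition:
compound 1, `CCCCCCCCS(=O)(=O)Nc1ccc(-c2ccccc2Cl)cc1C(=O)O`: 14400 nM
compound 2, `CCCCCCCCS(=O)(=O)Nc1ccc(-c2cccc(Cl)c2)cc1C(=O)O`: 8900 nM
compound 3, `CCCCCCCCS(=O)(=O)Nc1ccc(C(=O)c2ccc(OC)cc2)cc1C(=O)O`: 44300 nM

Compound 3 gives the highest number of the three in this assay, with compound 1 nearest and compound 2 furthest. The steps run a 3.1-fold higher number from compound 1 to compound 3 (0.49 log units; beyond the scatter) and a 5.0-fold higher number from compound 2 to compound 3 (0.70 log units; beyond the scatter); the step of a 1.6-fold lower number from compound 1 to compound 2 (0.21 log units; within the scatter) sits within the scatter.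

Compound 4, `CCCCCCCCS(=O)(=O)Nc1ccc(CCc2ccc(OC)cc2)cc1C(=O)O`, is not yet measured. It differs from compound 3 in one place: 2-(4-methoxyphenyl)ethyl in place of (4-methoxyphenyl)carbonyl on an aromatic carbon.

For the measured compounds named here, none of the measured steps tests this change directly. The steps into compound 3 exchange the whole chlorophenyl group for the (4-methoxyphenyl)carbonyl group, and both are modest in size; they show where compound 3 stands but say nothing about swapping the carbonyl for the 2-(4-methoxyphenyl)ethyl linker while the 4-methoxyphenyl part is kept. The working expectation for compound 4 in this assay is therefore a number close to that of compound 3, with any step a 1.8-fold lower number from compound 3 to compound 4 (0.25 log units; within the scatter) expected to lie near or within the scatter and the wider range leaning toward lower numbers, since all other measured numbers in the set lie below compound 3. Compound 4 is estimated at 25000 nM, within 8000 nM to 80000 nM.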

Compound 4, half-maximal inhibitory concentration: 26300 nM
Compound 4: middle estimate off by 1.1-fold (0.02 log units), on the low side; measured number inside the range.
By their numbers in this assay, from the lowest: compounds 2, 1, 4 and 3 (each within the scatter of the next, the first and the last beyond it).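

In this assay, the change at this position removes the carbonyl and keeps the 4-methoxyphenyl part, and the step stays within the scatter (a 1.7-fold lower number from compound 3 to compound 4 (0.23 log units; within the scatter)); at this level of inhibition, the number therefore does not depend on the carbonyl, even though the entering group has one hydrogen-bond acceptor fewer and no double bond outside the aromatic ring. Compared with the chlorophenyl compounds, the 2-(4-methoxyphenyl)ethyl group gives a split picture: the step from the 3-chlorophenyl group lies beyond the scatter (a 3.0-fold higher number from compound 2 to compound 4 (0.47 log units; beyond the scatter)), whereas the step from the 2-chlorophenyl group lies within it (a 1.8-fold higher number from compound 1 to compound 4 (0.26 log units; within the scatter)). No measurement available here bears on the reason for any of these steps.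

Open, going by these compounds, is whether other linkers at this position, such as an amide or a longer three-carbon chain, would also stay within the scatter of compound 3 and compound 4. Also open, on these data alone, is whether the 4-methoxyphenyl part matters once the ethyl linker is in place, which a 2-(3-chlorophenyl)ethyl group or a terminal carboxylic acid on the same linker would address.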